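The source may report more compounds than this note shows. Statements on the series, on what has been measured and on what is new or still open speak of the compounds shown alone.

Measured compounds:
Compound 1 `O=C(NC1CCCCC1)NS(=O)(=O)N1CCC(CCNC(=O)c2cscn2)CC1` gives 23% in a functional assay on the whole organism (blood) with Rattus norvegicus as the target, with stated times of 24 h and 1 h, at a dose of 5 mg/kg by the intraperitoneal route; on this read-out lower numbers stand for a weaker effect and higher numbers for a stronger effect at the one dose given.
Compound 2 `O=C(NC1CCCCC1)NS(=O)(=O)N1CCC(CCNC(=O)c2csnn2)CC1` gives 19%.
Compound 3 `O=C(NC1CCCCC1)NS(=O)(=O)N1CCC(CCNC(=O)c2ccnc3ccccc23)CC1` gives 16%.

Compound 3 holds the lowest of the three numbers, yet its distance to either neighbour is small: the steps of a number 7 percentage points lower from compound 1 to compound 3 (within the scatter) and a number 3 percentage points lower from compound 2 to compound 3 (within the scatter) both stay within the scatter, as does a number 4 percentage points lower from compound 1 to compound 2 (within the scatter). On these numbers the three aromatic groups on the carbonyl carbon cannot be told apart.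

Compound 4 `O=C(NC1CCCCC1)NS(=O)(=O)N1CCC(CCNC(=O)c2cccc3c2OCCO3)CC1` is the next step from compound 3. The change is 2,3-dihydro-1,4-benzodioxin-5-yl in place of quinolin-4-yl on a carbonyl carbon. The measured steps that bear on it are those in which the group on this carbonyl carbon was exchanged, namely a number 7 percentage points lower from compound 1 to compound 3 (within the scatter) and a number 3 percentage points lower from compound 2 to compound 3 (within the scatter), and neither went beyond the scatter. Since no exchange at this position has yet moved the read-out, a step of the same kind is expected here, that is none beyond the scatter in this assay, in no firm direction, giving a number 3 percentage points higher from compound 3 to compound 4 (within the scatter).

Compound 4 is therefore estimated at 19%, within 8% to 32%.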

Compound 4, a percentage reported as activity, at one dose (the size of the read-out at that dose, not a potency): 34%
The estimate for compound 4 lay 15 percentage points below the measured number, outside the stated range (above it).
By their numbers in this assay, from the lowest: compounds 3, 2 and 1 (each within the scatter of the next); then compound 4.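

In this assay, among these compounds, the group on the carbonyl carbon moves the read-out beyond the scatter for the first time: 2,3-dihydro-1,4-benzodioxin-5-yl gives a number 18 percentage points higher from compound 3 to compound 4 (beyond the scatter) and a number 15 percentage points higher from compound 2 to compound 4 (beyond the scatter) and also a number 11 percentage points higher from compound 1 to compound 4 (beyond the scatter) in the same assay. This position is therefore not indifferent to exchange, and the entering group alone among the four carries a six-membered non-aromatic ring with 2 hetero atoms. Nothing available accounts for the higher number.

Going by these compounds, it stays open whether a phenyl or a methoxyphenyl group on the carbonyl carbon would give a number like that of compound 4, and so whether the oxygens of the entering group matter at all. Equally open, on these data alone, is what an amine or a carboxylic acid in place of the cyclohexyl group would do to compound 4.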